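Cytotoxicity of Two Nucleoside Analogues and an Unmeasured Amide

A few compounds are considered here, and "the series" means these few. Any claim that something is new, unique, unknown or untested is made for them only; others in the source may bear on it.

Compound 1 `Cc1cn([C@@H]2O[C@H](CO[Si](C)(C)C(C)(C)C)[C@@]3(OS(=O)(=O)C=C3NCC(=O)C(=O)N3CCC3)[C@H]2O[Si](C)(C)C(C)(C)C)c(=O)n(C)c1=O` and compound 2 `COC(=O)CC(=O)NC1=CS(=O)(=O)O[C@@]12[C@@H](CO[Si](C)(C)C(C)(C)C)O[C@@H](n1cc(C)c(=O)n(C)c1=O)[C@@H]2O[Si](C)(C)C(C)(C)C` share a common core. In a functional assay on CCRF-CEM cells (Homo sapiens) (on this read-out higher numbers stand for lower toxicity in this test and lower numbers for higher toxicity in this test), compound 1 gives 21600 nM, and compound 2 gives 29700 nM. Compound 2 has the higher of the two numbers measured in this assay, but the difference a 1.4-fold higher number from compound 1 to compound 2 (0.14 log units; within the scatter) is within the scatter, so the two compounds cannot be told apart on this read-out.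

Compound 3 `Cc1cn([C@@H]2O[C@H](CO[Si](C)(C)C(C)(C)C)[C@@]3(OS(=O)(=O)C=C3NCC(=O)C(N)=O)[C@H]2O[Si](C)(C)C(C)(C)C)c(=O)n(C)c1=O` differs from compound 2 only on the amine nitrogen: (carbamoylcarbonyl)methyl in place of ((methoxycarbonyl)methyl)carbonyl on an amine nitrogen. Within the data shown here, the sole measured step, from compound 1 to compound 2, also exchanged the group on this amine nitrogen and stayed within the scatter, as a 1.4-fold higher number from compound 1 to compound 2 (0.14 log units; within the scatter) shows. On that basis compound 3 is expected to lie close to compound 2 in this assay, with the estimated step of a 1.2-fold lower number from compound 2 to compound 3 (0.07 log units; within the scatter) not beyond the scatter. Compound 3 is therefore estimated at 25000 nM, with a range from 10000 nM to 60000 nM.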

Compound 3, half-maximal cytotoxic concentration: 9960 nM
For compound 3 the middle estimate is 2.5-fold (0.40 log units) above the measured one; the measured number lies below the stated range.
By their numbers in this assay, from the lowest: compound 3; then compounds 1 and 2 (each within the scatter of the next).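

The amine nitrogen turned out to be able to shift the number beyond the scatter in this assay, which the exchange between compound 1 and compound 2 had not shown: (carbamoylcarbonyl)methyl in place of ((methoxycarbonyl)methyl)carbonyl gave a modest step (a 3.0-fold lower number from compound 2 to compound 3 (0.47 log units; beyond the scatter)). Within the same substituent, amino in place of azetidin-1-yl on a carbonyl carbon also gave a modest step beyond the scatter (a 2.2-fold lower number from compound 1 to compound 3 (0.34 log units; beyond the scatter)), so this outer end of the group affects the read-out too, in the direction of higher toxicity in this test. Nothing available here accounts for either step.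

The compounds shown leave open whether methylamino or dimethylamino on that carbonyl carbon would stay with compound 3 or return towards compound 1. They also leave open how a carboxylic acid or a longer chain at this end of the group would read in this test.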